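A few compounds are considered here, and "the series" means these few. Any claim that something is new, unique, unknown or untested is made for them only; others in the source may bear on it.

Measured compounds:
Compound 1, `CC1=CC[C@@H]([C@@](C)(O)CCCC(C)(C)NC(=S)N/N=C\c2ccccc2)CC1`: in a functional assay on HT-29 cells (Homo sapiens) for cytotoxicity, read by sulforhodamine B assay (on this read-out higher numbers stand for weaker inhibition of growth and lower numbers for stronger inhibition of growth), compound 1 gives 36500 nM.
Compound 2, `CC1=CC[C@@H]([C@@](C)(O)CCCC(C)(C)NC(=S)N/N=C\c2ccc(O)cc2)CC1`: in this assay compound 2 gives 31500 nM.

Compound 2 and compound 1 lie within the scatter of each other in this assay, the step being a 1.2-fold lower number from compound 1 to compound 2 (0.06 log units; within the scatter). Compound 3, `CC1=CC[C@@H]([C@@](C)(O)CCCC(C)(C)NC(=S)N/N=C\c2ccc(N(C)C)cc2)CC1`, differs from compound 2 by dimethylamino in place of hydroxy on an aromatic carbon. Within the data shown here, the only measured step that bears on this position is a 1.2-fold lower number from compound 1 to compound 2 (0.06 log units; within the scatter), a change at the same aromatic carbon, and it stayed within the scatter. Among the measured compounds shown here, no measured pair shows a dimethylamino group against a hydroxy group, so no direction can be read from the data. The expectation for compound 3 is therefore a step of about a 1.1-fold lower number from compound 2 to compound 3 (0.02 log units; within the scatter) in this assay, that is, nothing beyond the scatter. Compound 3 is accordingly estimated at 30000 nM, with a range from 12000 nM to 75000 nM.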

Compound 3, concentration for total growth inhibition: > 100000 nM
Compound 3 was reported as a limit (the forecaster's own chance of this, stated with the estimate: 5%); middle value at least 3.3-fold (0.52 log units) from the limit.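

The aromatic carbon para to a large group is not indifferent to what it carries in this assay: hydroxy in place of hydrogen stayed within the scatter, at a 1.2-fold lower number from compound 1 to compound 2 (0.06 log units; within the scatter), but dimethylamino moves the read-out beyond it, towards weaker inhibition of growth. Dimethylamino gives an at least 3.1-fold higher number from compound 2 to compound 3 (0.50 log units; beyond the scatter) against hydroxy and an at least 2.7-fold higher number from compound 1 to compound 3 (0.43 log units; beyond the scatter) against hydrogen, so the change counts against either group it replaces. The reading for compound 3 is a limit of the assay and not a number, so both steps give only their smallest possible size: the limit of > 100000 nM in this assay, at which 1 of the 3 values shown sits.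

The compounds shown leave open how far beyond that limit compound 3 lies. They also leave open whether a plain amino group, a methoxy group or a chlorine atom on this carbon would behave like hydroxy or like dimethylamino.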